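Lengthening the acid chain of compound 2

A few compounds are considered here, and "the series" means these few. Any claim that something is new, unique, unknown or untested is made for them only; others in the source may bear on it.

For the measured compounds named here, in a functional assay on MCF7 cells (Homo sapiens) for antiproliferative activity, read by MTT assay, with a stated time of 24 h (a lower number here means a stronger inhibitor, a higher number a weaker inhibitor), compound 1 (`CCn1c(C(=O)NCCO)ccc1C(CC)(CC)c1ccc(OCS(=O)(=O)c2ccccc2)c(C)c1`) gives 15500 nM and compound 2 (`CCn1c(C(=O)NCC(=O)O)ccc1C(CC)(CC)c1ccc(OCS(=O)(=O)c2ccccc2)c(C)c1`) gives 33100 nM as the higher of the two numbers so far. Compound 3 (`CCn1c(C(=O)NCCC(=O)O)ccc1C(CC)(CC)c1ccc(OCS(=O)(=O)c2ccccc2)c(C)c1`) has not yet been measured. It differs by carboxymethyl in place of carboxy on a saturated chain carbon bound to an amide-type nitrogen as carboxymethyl in place of carboxy on a saturated chain carbon bound to an amide-type nitrogen, so that (carboxymethyl)carbamoyl becomes (2-carboxyethyl)carbamoyl. Going by the values given here, the only measured step at this place is the modest 2.1-fold higher number from compound 1 to compound 2 (0.33 log units; beyond the scatter) for carboxy in place of hydroxymethyl. Resting on that one step, a shift of similar or smaller size is expected in this assay with no firm direction. The expected shift is a 1.2-fold lower number from compound 2 to compound 3 (0.07 log units; within the scatter) and lies within the scatter. Compound 3 is estimated at 28000 nM with an expected range from 12000 nM to 60000 nM for now.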

Compound 3, half-maximal inhibitory concentration: > 50000 nM
Compound 3 ended at the assay's limit (the forecaster's own chance of this, stated with the estimate: 10%); middle value at least 1.7-fold (0.25 log units) from the limit.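

In this assay compound 3 reads as a limit of the assay and not as a number: the limit of > 50000 nM in this assay, at which 1 of the 3 values shown sits.

Lengthening the acid chain gives an at least 1.5-fold higher number from compound 2 to compound 3 (0.17 log units; that floor lies within the scatter), so carboxymethyl in place of carboxy is not shown to raise the number beyond the scatter, and no lower number appears. The firmer reading is carboxy in place of hydroxy, with an at least 3.2-fold higher number from compound 1 to compound 3 (0.50 log units; beyond the scatter), so both acid-bearing chains now read higher than the hydroxy-bearing compound 1, each by a step printed beyond the scatter, and neither acid goes against this.

As far as these compounds go, whether an amine in place of the carboxy on this chain would read like compound 1 or like the acids remains open. From the compounds shown here alone, with compound 3 at a limit, the true size of the chain-lengthening step also stays unknown.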